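A few compounds are considered here, and "the series" means these few. Any claim that something is new, unique, unknown or untested is made for them only; others in the source may bear on it.

Of the compounds shown here, three from one series have been tested for their ability to slow the growth of a human lung cancer cell line. Compound 1 `Cc1cc(NS(=O)(=O)c2ccc(NCc3coc4ccccc4c3=O)cc2)no1` and compound 2 `Cc1cc(C)nc(NS(=O)(=O)c2ccc(NCc3coc4ccccc4c3=O)cc2)n1` share a core and differ only at one ring on the sulfonamide nitrogen. In a functional assay on A549 cells (Homo sapiens) for cytotoxicity, read by sulforhodamine B assay, with a stated time of 72 h (on this read-out higher numbers stand for weaker inhibition and lower numbers for stronger inhibition), compound 1 gives 59700 nM, while compound 2 gives 55800 nM. The change from compound 2 to compound 1 is 5-methyl-1,2-oxazol-3-yl in place of 4,6-dimethylpyrimidin-2-yl on a sulfonamide nitrogen, and the step it made is a 1.1-fold higher number from compound 2 to compound 1 (0.03 log units; within the scatter). Compound 3 `Cc1cc(C)nc(NS(=O)(=O)c2ccc(N3C(=O)/C(=C/c4coc5ccccc5c4=O)N=C3c3ccc(Cl)cc3)cc2)n1` carries a larger, more elaborate core; how that core differs from the core of compound 2 is not broken down here. In this assay compound 3 gives 52600 nM, and its value and those of compound 1 and compound 2 all lie within the usual scatter of one another.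

Compound 4 `Cc1cc(NS(=O)(=O)c2ccc(N3C(=O)/C(=C/c4coc5ccccc5c4=O)N=C3c3ccc(Cl)cc3)cc2)no1` has not yet been measured in this assay. It differs from compound 3 by 5-methyl-1,2-oxazol-3-yl in place of 4,6-dimethylpyrimidin-2-yl on a sulfonamide nitrogen, which is the same change, at the same place, as that made from compound 2 to compound 1. Because that earlier step was a 1.1-fold higher number from compound 2 to compound 1 (0.03 log units; within the scatter), the expected step from compound 3 to compound 4 is a 1.0-fold higher number from compound 3 to compound 4 (0.02 log units; within the scatter), essentially no change, although this rests on a single measured pair. On that basis compound 4 is estimated to give 55000 nM, with a plausible range from 30000 nM to 100000 nM.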

Compound 4, half-maximal inhibitory concentration: > 100000 nM
Compound 4 was reported as a limit (the forecaster's own chance of this, stated with the estimate: 15%); middle value at least 1.8-fold (0.25 log units) away from the limit.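

In this assay compound 4 gives > 100000 nM, which is a limit of the assay and not a true number. The step that this limit allows is an at least 1.9-fold higher number from compound 3 to compound 4 (0.27 log units; that floor lies within the scatter), so only a floor can be given for the change on the larger core, and even that floor does not clear the usual scatter. The result therefore does not show that swapping 4,6-dimethylpyrimidin-2-yl for 5-methyl-1,2-oxazol-3-yl on the sulfonamide nitrogen has the same effect on both cores, nor does it show that the effect differs, and each core offers only one pair of compounds: the same change on two cores in this assay, a 1.1-fold higher number (0.03 log units; within the scatter) from compound 2 to compound 1 and an at least 1.9-fold higher number (0.27 log units; that floor lies within the scatter) from compound 3 to compound 4; the limit leaves it open whether they differ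

The compounds shown leave open how other groups on the sulfonamide nitrogen would behave on these two cores, for example a pyridin-2-yl ring, a thiazol-2-yl ring or a plain methyl group. They also leave open whether the swap would give a similar step on any third core, since a rule for carrying a change from core to core needs more than two pairs, and both of these pairs sit at weak values in this one cell line.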